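The source may hold more compounds than are shown below. What is called first, only, known or untested is meant among the compounds shown, and "the series" means these compounds.

Measured compounds:
Compound 1 `C=C[C@@](C)(/C=C/c1ccc(O)cc1)CC/C=C(C)/C=C/C(=O)OCC` gives a limit in a functional assay on Raji cells (Homo sapiens) for cytotoxicity, with a stated time of 72 h; on this read-out lower numbers stand for an effect already at smaller amounts and higher numbers for an effect only at larger amounts of compound: > 26000 nM.
Compound 2 `C=C[C@@](C)(/C=C/c1ccc(O)cc1)CC/C=C(C)/C=C/C(=O)OCc1ccccc1` gives a limit in this assay: > 26000 nM.
Compound 3 `C=C[C@@](C)(/C=C/c1ccc(O)c(/C=C/C(=O)OCC)c1)CCC=C(C)C` gives a limit in this assay: > 26000 nM.

Compound 2 carries the change phenyl in place of methyl on a saturated chain carbon bound to an oxygen next to a carbonyl group relative to compound 1. The step that the two limits leave unreadable from compound 1 to compound 2 cannot be read because of the limit of > 26000 nM in this assay, at which 3 of the 3 values shown sit. Compound 3 carries a different core; the difference between the two cores is not broken down here. Compound 4 `C=C[C@@](C)(/C=C/c1ccc(O)c(/C=C/C(=O)OCc2ccccc2)c1)CCC=C(C)C` is not yet measured and carries the change phenyl in place of methyl on a saturated chain carbon bound to an oxygen next to a carbonyl group relative to compound 3, the same change as from compound 1 to compound 2. The expected step that the limit leaves unreadable from compound 3 to compound 4 rests on the limit of > 26000 nM in this assay, at which 3 of the 3 values shown sit, at which compound 1 and compound 2 both sit, which leaves the change unreadable in this core. Compound 4 is therefore estimated at 40000 nM, with the range 15000 nM to 120000 nM, and most likely again only a limit.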

Compound 4, half-maximal effective concentration: > 26000 nM
Compound 4: no number, only a limit; the forecaster's own chance of this, stated with the estimate: 85%; the middle value lies beyond the limit too.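

The step between compound 3 and compound 4 in this assay cannot be read, because both rest on a limit: the limit of > 26000 nM in this assay, at which 4 of the 4 values shown sit. The compounds shown leave open whether phenyl in place of methyl changes the effect in either core, and at what concentration any of them acts in this assay.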